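This account rests on a few compounds, and the source may have more. Where it says the series, first, only, none or still open, it means among the compounds named here.

Working notes on the series. Of the compounds shown here, two have so far been measured in a functional assay on T47D cells (Homo sapiens) for cytotoxicity, read by CCK-8 assay; on this read-out higher numbers stand for weaker inhibition and lower numbers for stronger inhibition. Compound 1 `Oc1ccc(-c2cc(-c3ccoc3)cc(-c3ccccc3O)n2)cc1` reaches only the limit of the assay, giving > 50000 nM in this assay. Compound 2 `Oc1ccccc1-c1cc(-c2ccccn2)cc(-c2ccccc2O)n1` likewise returns a limit rather than a number, > 50000 nM in this assay. Where compound 2 stands is therefore only a boundary: the limit of > 50000 nM in this assay, at which 2 of the 2 values shown sit. Going by the values given here, no step between measured compounds can be counted, as both sit at the same limit. Compound 3 `Oc1ccc(-c2cc(-c3ccccn3)cc(-c3ccccc3O)n2)cc1` is not yet measured; it differs from compound 2 by 4-hydroxyphenyl in place of 2-hydroxyphenyl on an aromatic carbon, in words 4-hydroxyphenyl in place of 2-hydroxyphenyl on an aromatic carbon. Compound 1 also carries a 4-hydroxyphenyl group and sits at the limit; from this change no move beyond the scatter is expected in this assay. For compound 3 the expected result is 60000 nM in this assay, within 20000 nM to 200000 nM, most probably reported again only as a limit. The expected step is a step that the limit leaves unreadable from compound 2 to compound 3, essentially none.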

Compound 3, half-maximal inhibitory concentration: > 50000 nM
Compound 3 ended at the assay's limit (the forecaster's own chance of this, stated with the estimate: 80%); the middle value does not contradict the limit.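

Going by these compounds alone, no step among compound 1, compound 2 and compound 3 can be read, as all three return only a limit in this assay: the limit of > 50000 nM in this assay, at which 3 of the 3 values shown sit. The compounds shown leave open whether any change to the shared core gives a measurable value in this assay.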